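The source may report more compounds than this note shows. Statements on the series, on what has been measured and on what is new or still open speak of the compounds shown alone.

In a functional assay on PANC-1 cells (Homo sapiens) for cytotoxicity, read by fluorescence, with a stated time of 24 h (on this read-out higher numbers stand for weaker inhibition and lower numbers for stronger inhibition), compound 3 `CC(C)=CCCC1(C)CCc2c(CCC(=O)c3ccc(O)cc3O)ccc(O)c2O1` gives 59500 nM. Compound 1 `CC(C)=CCC/C(C)=C/Cc1c(CCC(=O)c2ccc(O)cc2O)ccc(O)c1O` gives 42900 nM, within the scatter of compound 3 . Compound 2 `COC(C)(C)CCC/C(C)=C/Cc1c(CCC(=O)c2ccc(O)cc2O)ccc(O)c1O` gives > 75000 nM, which is a limit of the assay and not a number.

The change from compound 3 to compound 4 `CC(C)(O)CCCC1(C)CCc2c(CCC(=O)c3ccc(O)cc3O)ccc(O)c2O1` is 2-hydroxy-2-methylpropyl in place of 2-methylprop-1-en-1-yl on a saturated chain carbon, two bonds along the chain from a saturated ring carbon. Going by the values given here, the one measured step that bears on it replaces the same 2-methylprop-1-en-1-yl with 2-methoxy-2-methylpropyl, and it reads an at least 1.7-fold higher number from compound 1 to compound 2 (0.24 log units; that floor lies within the scatter). That step is only a floor, it ends in a methoxy group rather than a hydroxy group, and it sits at a different place, so it gives weak guidance on direction. A small move towards higher numbers in this assay is therefore expected, not clearly beyond the scatter, and a reading that is only a limit would be no surprise. The expected step is a 1.3-fold higher number from compound 3 to compound 4 (0.13 log units; within the scatter). For compound 4 the estimated value is 80000 nM, with an expected range of 45000 nM to 150000 nM.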

Compound 4, half-maximal inhibitory concentration: 36700 nM
For compound 4 the middle estimate is 2.2-fold (0.34 log units) above the measured one, and the stated range ends above it.
By their numbers in this assay, from the lowest: compounds 4, 1 and 3 (each within the scatter of the next). At a limit, above all of these: compound 2.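

In this assay, 2-hydroxy-2-methylpropyl in place of 2-methylprop-1-en-1-yl, on a saturated chain carbon, two bonds along the chain from a saturated ring carbon, gives a 1.6-fold lower number from compound 3 to compound 4 (0.21 log units; within the scatter). At this position, then, the double bond can give way to a hydroxy-bearing saturated end with no change that can be told from the scatter, and the reading of compound 4 stays a number rather than a limit. The reading of compound 2 is a limit and not a number, so the step to it sets only a floor and its true size stays unknown: the limit of > 75000 nM in this assay, at which 1 of the 4 values shown sits.

Open, going by these compounds, is how a hydroxy end would read on the core of compound 1, and how a methoxy end would read on the core of compound 3. Also open, on these data alone, is whether an amine or a carboxylic acid at this chain end, or a longer chain, would move the reading beyond the scatter.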